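This account rests on a few compounds, and the source may have more. Where it says the series, first, only, none or still open, it means among the compounds named here.

Measured in a functional assay on HT-29 cells (Homo sapiens) for inhibition, read by MTT assay; a higher number here means a weaker inhibitor, a lower number a stronger inhibitor
- compound 1 `COc1ccc(/C=C2\c3cc(OC)c(OC)c(OC)c3CC[C@@H]2O)cc1C#N` at 5 nM
- compound 2 `COc1ccc(/C=C2\c3cc(OC)c(OC)c(OC)c3CC[C@H]2O)cc1F` at 220 nM

Compound 2 holds the higher of the two numbers, beyond the scatter from compound 1, and is the weaker inhibitor of this pair. Compound 3 `COc1ccc(/C=C2\c3cc(OC)c(OC)c(OC)c3CC[C@H]2O)cc1C#N` departs from compound 2 in one place, with cyano in place of fluoro on an aromatic carbon. Among the compounds with values here, no measured pair differs in one place only, so the size of this change in this assay has no direct measure. Within the data shown here, the only measured cyano compound, compound 1 at 5 nM, points toward a lower number, and that single value is thin support. The expected change is a 4.4-fold lower number from compound 2 to compound 3 (0.64 log units; beyond the scatter) and would lie beyond the scatter, though with wide uncertainty. For compound 3 the estimated value is 50 nM with an expected range from 8 nM to 300 nM as its upper end.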

Compound 3, half-maximal inhibitory concentration: 200 nM
The estimate for compound 3 lay 4.0-fold (0.60 log units) below the measured number; measured number inside the range.
By their numbers in this assay, from the lowest: compound 1; then compounds 3 and 2 (each within the scatter of the next).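

In this assay, cyano in place of fluoro on this aromatic carbon, ortho to a methoxy group, gives a 1.1-fold lower number from compound 2 to compound 3 (0.04 log units; within the scatter), so with the stereocentre drawn R, this change separates the two compounds by no more than the scatter. The stereocentre at the saturated ring carbon counts for far more, with a 40-fold higher number from compound 1 to compound 3 (1.60 log units; beyond the scatter), and this large step can be assigned to that centre alone for one reason: the fact that compounds 1 and 3 differ only in the configuration as drawn. The low number of compound 1, at 5 nM, therefore cannot be credited to the cyano group alone.

On these data alone, whether fluoro at this position would also give a low number with the stereocentre drawn S remains open. Also open, as far as these compounds go, is whether an amine or a carboxylic acid on this aromatic carbon would respond to the configuration in the same way.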